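This account rests on a few compounds, and the source may have more. Where it says the series, first, only, none or still open, it means among the compounds named here.

Working notes on the series. Going by the values given here, in a functional assay on PC-3 cells (Homo sapiens) for inhibition, read by MTT assay, with a stated time of 24 h (a lower number here means a stronger inhibitor, a higher number a weaker inhibitor), compound 1 `Cc1ccc(-c2cc(/C=N/c3ccccc3)on2)cc1` gives 31600 nM and compound 2 `FC(F)(F)c1ccc(-c2cc(/C=N/c3ccccc3)on2)cc1` gives 35700 nM; the one measured step, a 1.1-fold higher number from compound 1 to compound 2 (0.05 log units; within the scatter), is a change on an aromatic carbon of a core different from that of compound 3. Compound 3 `CCc1cc2ccccc2nc1-c1cc(-c2ccccc2)no1` returns only a limit, > 100000 nM, in this assay, so it stands at the limit of > 100000 nM in this assay, at which 1 of the 3 values shown sits, and no number places it against compounds 1 and 2. Compound 4 `CCCCCc1cc2ccccc2nc1-c1cc(-c2ccccc2)no1` carries the change (propyl in place of hydrogen on a saturated chain carbon, two bonds along the chain from an aromatic carbon). Among the compounds with values here, no measured step concerns a chain extension of this kind on the core of compound 3, so the expectation rests on the limit of compound 3 alone. For compound 4 the expected step is a number no higher from compound 3 to compound 4 (the limit leaves the size open), with the outcome most likely again a limit. Compound 4 is estimated at 100000 nM, within 30000 nM to 300000 nM.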

Compound 4, half-maximal inhibitory concentration: > 100000 nM
Compound 4: no number, only a limit; the forecaster's own chance of this, stated with the estimate: 65%; the middle value lies on the limit itself.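

Going by these compounds alone, compound 3 and compound 4 both return only a limit, so no step between them can be read: the limit of > 100000 nM in this assay, at which 2 of the 4 values shown sit. The compounds shown leave open whether any chain on the core of compound 3 gives a readable number.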